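Trading an Azidomethyl Arm for a Styryl Arm

This account rests on a few compounds, and the source may have more. Where it says the series, first, only, none or still open, it means among the compounds named here.

The measured compounds are:

compound 1 `NS(=O)(=O)c1cc(-c2nnc(CN3CCN(c4ccc(Cl)cc4)CC3)o2)c(Cl)cc1SCc1ccccc1` with 0.455 h
compound 2 `Cc1ccc(C)c(N2CCN(Cc3nnc(-c4cc(S(N)(=O)=O)c(SCc5ccccc5)cc4Cl)o3)CC2)c1` with 0.208 h
compound 3 `[N-]=[N+]=NCc1nnc(-c2cc(S(N)(=O)=O)c(SCc3ccccc3)cc2Cl)o1` with > 1 h

All three values come from an ADME assay on microsomes from liver (Homo sapiens) for metabolic stability, read by LC-MS, using NADPH, tested at 5 uM; on this read-out higher numbers stand for a longer-lived compound and lower numbers for a shorter-lived compound. Compound 1 gives 0.455 h in this assay, and compound 2 gives 0.208 h, a shift of a 2.2-fold lower number from compound 1 to compound 2 (0.34 log units; beyond the scatter). For compound 3 this assay reports only a limit, > 1 h, which is the point noted as the limit of > 1 h in this assay, at which 1 of the 3 values shown sits, and not a number; compound 3 thus sits at the long-lived end of the three, with its true half-life unknown.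

Compound 4 `NS(=O)(=O)c1cc(-c2nnc(/C=C/c3ccccc3)o2)c(Cl)cc1SCc1ccccc1` has not yet been measured. It differs from compound 3 in one place: 2-phenylethenyl in place of azidomethyl on an aromatic carbon

Going by the values given here, the single measured step, from compound 1 to compound 2, alters the aryl group on the amine nitrogen in a ring, a different place from the one changed here, so no measured step bears directly on the move from compound 3 to compound 4. The two numbered values of compound 1 and compound 2 both lie well under the limit reached by compound 3, and the expectation is that compound 4 falls back toward those, a step of an at least 1.6-fold lower number from compound 3 to compound 4 (0.22 log units; that floor lies within the scatter). Compound 4 is therefore estimated at 0.6 h, within a range from 0.25 h to 1 h.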

Compound 4, half-life: 0.228 h
Beside the measured number, compound 4's estimate is 2.6-fold (0.42 log units) above it, and the stated range ends above it.
By their numbers in this assay, from the lowest: compounds 2, 4 and 1 (each within the scatter of the next, the first and the last beyond it). At a limit, above all of these: compound 3.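

The earlier step changed only the aryl group on the amine nitrogen in a ring, whereas this change sits on the aromatic carbon of the five-membered ring, and in this assay replacing azidomethyl with 2-phenylethenyl gives an at least 4.3-fold lower number from compound 3 to compound 4 (0.64 log units; beyond the scatter). With 2-phenylethenyl in place, compound 4 gives 0.228 h, which lies within the scatter of compound 1 and of compound 2, so in this read-out it cannot be told apart from either, although its arm carries neither the amine ring nor its aryl group. The half-life therefore responds to this position too, but the true size of the step stays unknown, since compound 3 stands at a limit and not at a number: the limit of > 1 h in this assay, at which 1 of the 4 values shown sits.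

The compounds shown do not separate the double bond of 2-phenylethenyl from its six-membered aromatic ring as the part that carries the step. As far as these compounds go, how a saturated 2-phenylethyl arm or a plain methyl group on the same carbon would read also stays open.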